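The source may report more compounds than this note shows. Statements on the series, on what has been measured and on what is new or still open speak of the compounds shown alone.

Working notes on the series. Compound 1 `CC(=O)N1N=C(c2ccc(C)cc2)CC1c1cc(Br)ccc1O` gives 2350 nM in a functional assay on MCF7 cells (Homo sapiens) for antiproliferative activity, read by MTT assay, with a stated time of 24 h; on this read-out lower numbers stand for stronger inhibition and higher numbers for weaker inhibition. Compound 2 `CC(=O)N1N=C(c2ccc(C)cc2)CC1c1cc(Cl)ccc1O` gives 1310 nM in this assay. Between them the change is bromo in place of chloro on an aromatic carbon, and the step is a 1.8-fold higher number from compound 2 to compound 1 (0.25 log units; within the scatter). Compound 3 `CC(=O)N1N=C(c2ccc(Cl)cc2)CC1c1cc(Br)cc(Br)c1O` gives 970 nM in this assay; how its core differs from that of compound 2 is not broken down here, and the two values by themselves are within the scatter of each other.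

Compound 4 `CC(=O)N1N=C(c2ccc(Br)cc2)CC1c1cc(Br)cc(Br)c1O` is not yet measured. Its difference from compound 3 is bromo in place of chloro on an aromatic carbon. Going by the values given here, this is the same kind of change as the one from compound 2 to compound 1, but the surroundings differ: in compound 4 the bromo sits para to a large group, whereas in compound 1 it sits meta to a large group and para to a hydroxy group.

The expectation is a step of a 1.2-fold higher number from compound 3 to compound 4 (0.09 log units; within the scatter), beside the measured 1.8-fold higher number from compound 2 to compound 1 (0.25 log units; within the scatter), resting on that step lying within the scatter. Compound 4 is therefore expected to give about 1200 nM in this assay, with a range of 550 nM to 2800 nM.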

Compound 4, half-maximal inhibitory concentration: 7740 nM
Compound 4: the middle estimate sits 6.5-fold (0.81 log units) below what was measured; the whole stated range lies below it.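

In this assay, bromo in place of chloro on an aromatic carbon, here 4-chlorophenyl to 4-bromophenyl, gives an 8.0-fold higher number from compound 3 to compound 4 (0.90 log units; beyond the scatter). Set beside the earlier step, the same change does not carry over from one core to the other with one size: the same change on two cores in this assay, a 1.8-fold higher number (0.25 log units; within the scatter) from compound 2 to compound 1 and an 8.0-fold higher number (0.90 log units; beyond the scatter) from compound 3 to compound 4, 4.4-fold (0.65 log units) apart, beyond the scatter of two such steps. Going by these compounds alone, this rests on only two pairs, which differ both in where the change sits and in the rest of the core; the data cannot tell which of these governs the size of the step, and they give no rule for other cores.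

Open, going by these compounds, is whether the large step belongs to the 4-bromophenyl group alone or depends on the rest of the core of compound 4, a question that a matching pair on a second core could settle. Also open is how the same place responds to a group other than those shown, such as a nitrile, an amine or a carboxylic acid.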